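Benzylic carbon variation in a sulfonamide series

The source may hold more compounds than are shown below. What is called first, only, known or untested is meant among the compounds shown, and "the series" means these compounds.

Compound 2 `CCS(=O)(=O)N(Cc1cccnc1)c1cccc(C(=O)c2ccccc2)c1` gives 1100 nM in an assay on isolated protein with metabotropic glutamate receptor 2 (Homo sapiens) as the target (a lower number here means that less compound is needed, a higher number that more compound is needed for the effect), the lowest of the two numbers seen so far. Compound 3 `CCS(=O)(=O)N(Cc1cccnc1)c1ccc(Cc2ccccc2)cc1` gives 1600 nM in this assay, which sits within the scatter of compound 2. Compound 1 `CCS(=O)(=O)N(Cc1cccnc1)c1ccc(C(O)c2ccccc2)cc1` reaches only > 30000 nM in this assay, a limit rather than a number, as shown by the limit of > 30000 nM in this assay, at which 1 of the 3 values shown sits. Among the measured compounds shown here, the one measured step, an at least 18-fold lower number from compound 1 to compound 3 (1.27 log units; beyond the scatter), shows that the saturated carbon bound to two aromatic carbons tolerates hydrogen far better than hydroxy.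

Compound 4 `CCS(=O)(=O)N(Cc1cccnc1)c1cccc(C(F)c2ccccc2)c1` carries fluoro(phenyl)methyl in place of benzoyl on an aromatic carbon. The carbonyl of compound 2 disappears and a fluorine takes a hydrogen on the new saturated carbon; the shown step concerns hydroxy rather than fluorine, so it bears on the change only loosely. A modest step in this assay is expected, from compound 2 to compound 4 a 2.3-fold higher number from compound 2 to compound 4 (0.36 log units; beyond the scatter), towards a somewhat higher number. Compound 4 is estimated at 2500 nM, in the range 800 nM to 8000 nM.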

Compound 4, half-maximal effective concentration: 180 nM
Beside the measured number, compound 4's estimate is 14-fold (1.14 log units) above it; the whole stated range lies above it.
By their numbers in this assay, from the lowest: compound 4; then compounds 2 and 3 (each within the scatter of the next). At a limit, above all of these: compound 1.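

Fluoro(phenyl)methyl in place of benzoyl on an aromatic carbon, meta to a large group, gives a 6.1-fold lower number from compound 2 to compound 4 (0.79 log units; beyond the scatter) in this assay, so at this position the carbonyl is not needed and a saturated carbon bearing fluorine is accepted. Among the compounds shown here, until now the only change read on the carbon linking the two aromatic rings was hydroxy against hydrogen, and that step comes from a pair differing from compound 4 in more than one place, so it says nothing direct about this position. Nothing shown accounts for the size of this step.

Open, as far as these compounds go, is how much of the step belongs to the fluorine and how much to the loss of the carbonyl. Also open, from the compounds shown here alone, is whether a methoxy or an amine on the same saturated carbon would be accepted.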